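The compounds below may be only part of what the source reports. "The series", "measured", "known", "first", "only" and "open" are said of these compounds alone.

Measured in a functional assay on Jurkat cells (Homo sapiens) for cytotoxicity, with a stated time of 72 h; on this read-out higher numbers stand for an effect only at larger amounts of compound and lower numbers for an effect already at smaller amounts:

- Compound 1 `C=C[C@@](C)(/C=C/c1ccc(OC)cc1)CCC=C(C)C`: > 49000 nM (a limit, not a number)
- Compound 2 `C=C[C@@](C)(/C=C/c1ccc(O)c(CO)c1)CCC=C(C)C`: > 49000 nM (a limit, not a number)

Compound 2 has no number of its own in this assay, and its reading of > 49000 nM is a limit of the assay. The whole of the evidence so far is the limit of > 49000 nM in this assay, at which 2 of the 2 values shown sit.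

The next compound is compound 3 `C=C[C@@](C)(/C=C/c1ccc(O)c(/C=C/C(N)=O)c1)CCC=C(C)C`. It has 2-carbamoylethenyl in place of hydroxymethyl on an aromatic carbon, ortho to a hydroxy group and meta to a large group: 2-carbamoylethenyl in place of hydroxymethyl on an aromatic carbon.

Among the measured compounds shown here, no measured step between compounds shows what a change at this place does, so any expectation here is tentative. A modest step toward effect at smaller amounts is expected in this assay, and it may be no larger than the scatter. Compound 3 may well stay at the limit as well. The expected size of the change is an at least 1.6-fold lower number from compound 2 to compound 3 (0.21 log units; that floor lies within the scatter). The estimated value for compound 3 is 30000 nM, with an expected range of 10000 nM to 49000 nM.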

Compound 3, half-maximal effective concentration: > 49000 nM
Compound 3 was reported as a limit; the forecaster's own chance of this, stated with the estimate: 60%; middle value at least 1.6-fold (0.21 log units) from the limit.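

In this assay compound 3 gives > 49000 nM, a limit and not a number. Among the compounds shown here, compound 2 also stands at a limit there, so no step between compound 2 and compound 3 can be read. The compounds shown leave open what 2-carbamoylethenyl in place of hydroxymethyl does, and where any of them would read as a number: the limit of > 49000 nM in this assay, at which 3 of the 3 values shown sit.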